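Replacing nitro with hydrogen in compound 2

The compounds below may be only part of what the source reports. "The series", "measured", "known", "first", "only" and "open" are said of these compounds alone.

In a functional assay on KBVIN cells (Homo sapiens) for antiproliferative activity, read by sulforhodamine B assay, with a stated time of 3 days (a lower number here means a stronger inhibitor of growth, a higher number a weaker inhibitor of growth), compound 1 (`O=C(Nc1ccccn1)c1cccc(Nc2ncc(F)c(Nc3ccc(F)cc3)n2)c1`) gives 13700 nM and compound 2 (`O=C(Nc1cccc(Nc2ncc(F)c(Nc3ccc(F)cc3)n2)c1)c1cccc([N+](=O)[O-])c1`) gives 11400 nM, two numbers within the usual scatter of each other. Within the data shown here, compound 2 therefore stands level with the only other measured compound. Compound 3 (`O=C(Nc1cccc(Nc2ncc(F)c(Nc3ccc(F)cc3)n2)c1)c1ccccc1`) has hydrogen in place of nitro on an aromatic carbon, meta to a large group: hydrogen in place of nitro on an aromatic carbon. Among the measured compounds shown here, no measured step shows this change, so the expectation is loose. The estimated 1.1-fold higher number from compound 2 to compound 3 (0.02 log units; within the scatter) is expected to stay within the scatter, with no clear direction. Compound 3 is expected at 12000 nM, within an estimated range of 6000 nM to 25000 nM.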

Compound 3, concentration for 50% growth inhibition: > 10000 nM
Compound 3 gave a limit, no number; the forecaster's own chance of this, stated with the estimate: 10%; the middle value is on the limit's open side.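

In this assay compound 3 gives > 10000 nM, a limit and not a number. The steps from compound 1 and compound 2 to compound 3 cannot be read. As far as these compounds go, whether hydrogen in place of nitro changes growth inhibition, and in which direction, stays open.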